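Para substituent swap on the cinnamoyl benzoxaborole series

This account rests on a few compounds, and the source may have more. Where it says the series, first, only, none or still open, it means among the compounds named here.

Values in a toxicity assay on MCF-10A cells (Homo sapiens) for cytotoxicity, read by MTT assay, with a stated time of 48 h; on this read-out higher numbers stand for weaker inhibition and lower numbers for stronger inhibition:
- Compound 1, `O=C(/C=C/c1ccc2c(c1)B(O)OC2)c1ccc(-c2ccccc2)cc1`: 20700 nM
- Compound 2, `Cn1cccc1C(=O)/C=C/c1ccc2c(c1)B(O)OC2`: gives only an assay limit, > 100000 nM
- Compound 3, `O=C(/C=C/c1ccc2c(c1)B(O)OC2)c1ccc(F)cc1`: 11800 nM

Compound 3 carries the lowest of the two numbers in this assay; its nearest neighbour is compound 1, and the step of a 1.8-fold lower number from compound 1 to compound 3 (0.24 log units; within the scatter) stays within the scatter. The step of an at least 8.4-fold lower number from compound 2 to compound 3 (0.92 log units; beyond the scatter) runs beyond the scatter, but compound 2 sits at the limit (the limit of > 100000 nM in this assay, at which 1 of the 3 values shown sits), so only a bound is known there.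

Compound 4, `O=C(/C=C/c1ccc2c(c1)B(O)OC2)c1ccc(I)cc1`, is the next member. Its difference from compound 3: iodo in place of fluoro on an aromatic carbon. Going by the values given here, no measured step exchanges one halogen for another at this position. Among the compounds with values here, the only step on the same carbon, from compound 1 to compound 3, replaced phenyl with fluoro and stayed within the scatter, which suggests this position tolerates a change of group size without a clear shift in the number.

Compound 4 is therefore expected to show a step of a 1.1-fold lower number from compound 3 to compound 4 (0.03 log units; within the scatter), not beyond the scatter. The estimate for compound 4 in this assay is 11000 nM, with a range from 4000 nM to 30000 nM.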

Compound 4, half-maximal inhibitory concentration: > 100000 nM
Compound 4 ended at the assay's limit; the forecaster's own chance of this, stated with the estimate: 5%; middle value at least 9.0-fold (0.95 log units) away from the limit.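

In this assay compound 4 gives > 100000 nM, which is a limit of the assay and not a number. The aromatic carbon para to a large group therefore does not tolerate every change: an at least 8.4-fold higher number from compound 3 to compound 4 (0.92 log units; beyond the scatter), and an at least 4.8-fold higher number from compound 1 to compound 4 (0.68 log units; beyond the scatter), whereas a 1.8-fold lower number from compound 1 to compound 3 (0.24 log units; within the scatter); fluoro and phenyl stay together on this read-out, and iodo, a single heavy atom exchanged for another, separates from both. The step from compound 2 to compound 4 cannot be read, with both compounds at the limit: the limit of > 100000 nM in this assay, at which 2 of the 4 values shown sit.

The true size of the two steps to compound 4 remains open, since each gives only a bound, and with fluoro as the only other halogen shown, it is also open whether the shift builds along the halogens or belongs to iodo alone. Chloro or bromo on the same carbon would bear on the halogen question, and an amine or a carboxylic acid there would test whether the loss of the number extends to groups of a different kind.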